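The source may report more compounds than this note shows. Statements on the series, on what has been measured and on what is new or still open speak of the compounds shown alone.

Measured in a functional assay on A549 cells (Homo sapiens) for antiproliferative activity, read by MTT assay, with a stated time of 24 h; on this read-out lower numbers stand for stronger inhibition and higher numbers for weaker inhibition:
compound 1, `Cc1ccccc1-n1cc(-c2cccc(NS(=O)(=O)c3c[nH]c(=O)[nH]c3=O)c2)nn1`, gives 5470 nM.
compound 2, `Cc1ccc(-n2cc(-c3cccc(NS(=O)(=O)c4c[nH]c(=O)[nH]c4=O)c3)nn2)cc1`, gives 3630 nM.
compound 3, `O=c1[nH]cc(S(=O)(=O)Nc2cccc(-c3cn(-c4ccccc4F)nn3)c2)c(=O)[nH]1`, gives > 20000 nM, which is a limit of the assay and not a number.

On the numbers shown compound 3 stands at the weak end of the set. Its value is only the assay limit (the limit of > 20000 nM in this assay, at which 1 of the 3 values shown sits), and the steps of an at least 3.6-fold higher number from compound 1 to compound 3 (0.56 log units; beyond the scatter) and an at least 5.5-fold higher number from compound 2 to compound 3 (0.74 log units; beyond the scatter) both run beyond the scatter toward weaker inhibition, while a 1.5-fold lower number from compound 1 to compound 2 (0.18 log units; within the scatter) stays within the scatter.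

Compound 4, `O=c1[nH]cc(S(=O)(=O)Nc2cccc(-c3cn(-c4ccccc4Cl)nn3)c2)c(=O)[nH]1`, differs from compound 3 by chloro in place of fluoro on an aromatic carbon. Among the compounds with values here, the steps that bear on this change are those in which the group on this phenyl is altered, an at least 3.6-fold higher number from compound 1 to compound 3 (0.56 log units; beyond the scatter) and an at least 5.5-fold higher number from compound 2 to compound 3 (0.74 log units; beyond the scatter), both of which moved the number upward by at least a modest amount. Within the data shown here, since compound 3 itself sits at the limit, a further upward step cannot be read, and a return toward the numbers of compound 1 or compound 2 has no measured pair behind it. No step beyond the scatter is therefore expected in this assay, and the expected step is a number no higher from compound 3 to compound 4 (the limit leaves the size open). For compound 4 the estimate is 20000 nM, with a range of 6000 nM to 60000 nM, and a fair chance that only a limit is again reported.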

Compound 4, half-maximal inhibitory concentration: 2730 nM
The estimate for compound 4 lay 7.3-fold (0.86 log units) above the measured number; the whole stated range lies above it.
By their numbers in this assay, from the lowest: compounds 4, 2 and 1 (each within the scatter of the next). At a limit, above all of these: compound 3.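

In this assay, chloro in place of fluoro on this carbon, ortho to a large group, gives an at least 7.3-fold lower number from compound 3 to compound 4 (0.86 log units; beyond the scatter), so a group at this place does not by itself take the series to the weak end of the set. Compound 4 instead falls in with the two methyl compounds, with a 1.3-fold lower number from compound 2 to compound 4 (0.12 log units; within the scatter) and a 2.0-fold lower number from compound 1 to compound 4 (0.30 log units; within the scatter), so on these numbers 2-chlorophenyl cannot be told apart from either 4-methylphenyl or 2-methylphenyl, and of the three groups tried on this carbon only fluoro stands apart. Compound 3 alone is separated from the others, and its > 20000 nM is a limit of the assay and not a number: the limit of > 20000 nM in this assay, at which 1 of the 4 values shown sits.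

From the compounds shown here alone, what sets fluoro apart from chloro and methyl on this carbon stays open, and the true size of the step from fluoro to chloro stays open with it. Also open, going by these compounds, is where a methoxy, a trifluoromethyl, a nitrile or an amine on this carbon would fall, that is, whether compound 3 is a single exception or the edge of a wider trend among such groups.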